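Notes on a chromone amide series, kinase inhibition

A few compounds are considered here, and "the series" means these few. Any claim that something is new, unique, unknown or untested is made for them only; others in the source may bear on it.

Measured so far:
compound 1 `O=C(COc1ccc2c(=O)ccoc2c1)Nc1cccc(NC(=O)c2ccc(F)cc2)c1` gives 129 nM
compound 2 `COc1ccc(C(=O)Nc2cccc(NC(=O)COc3ccc4c(=O)ccoc4c3)c2)cc1` gives 18 nM
compound 3 `O=C(COc1ccc2c(=O)ccoc2c1)Nc1cccc(NC(=O)c2ccc([N+](=O)[O-])cc2)c1` gives 67 nM

All three numbers come from an assay on isolated protein for inhibition of Rho-associated protein kinase 1 (Homo sapiens), read by scintillation counting, radiometric assay and 33P incorporation, with a stated time of 40 min, in the presence of a further agent that is not named here; a lower number here means a stronger inhibitor, a higher number a weaker inhibitor. Among them compound 3 stands second highest. The nearer neighbour is compound 1: a 1.9-fold lower number from compound 1 to compound 3 (0.28 log units; within the scatter). The further one is compound 2: a 3.7-fold higher number from compound 2 to compound 3 (0.57 log units; beyond the scatter). Within the data shown here, the only other step, a 7.2-fold lower number from compound 1 to compound 2 (0.86 log units; beyond the scatter), is also modest.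

Compound 4 `CC(C)(C)c1cc(C(=O)Nc2cccc(NC(=O)COc3ccc4c(=O)ccoc4c3)c2)no1` is the next entry. Its difference from compound 3 is 5-(tert-butyl)-1,2-oxazol-3-yl in place of 4-nitrophenyl on a carbonyl carbon. Among the measured compounds shown here, every measured step so far exchanges one substituent on the same six-membered aromatic ring of carbon only; none exchanges the ring itself, so no measured step speaks directly to this change. What the measured steps do show is that changes at this carbonyl carbon have moved this assay by at most a modest amount in either direction. On that basis a step of similar size is expected, with no firm direction: a 1.1-fold lower number from compound 3 to compound 4 (0.05 log units; within the scatter). Compound 4 is therefore estimated at 60 nM, with a range from 15 nM to 250 nM.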

Compound 4, half-maximal inhibitory concentration: 101 nM
For compound 4 the middle estimate is 1.7-fold (0.23 log units) below the measured one, and the stated range covers the measured number.
By their numbers in this assay, from the lowest: compound 2; then compounds 3, 4 and 1 (each within the scatter of the next).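

Among these compounds, the one exchange of the ring itself at this carbonyl carbon stays within the scatter of two of the earlier phenyl groups, with a 1.5-fold higher number from compound 3 to compound 4 (0.18 log units; within the scatter) and a 1.3-fold lower number from compound 1 to compound 4 (0.11 log units; within the scatter) in this assay. A five-membered aromatic ring with 2 hetero atoms and a tert-butyl group therefore reads much like 4-nitrophenyl and 4-fluorophenyl at this place, while 4-methoxyphenyl stays apart from it, with a 5.6-fold higher number from compound 2 to compound 4 (0.75 log units; beyond the scatter). No measurement at hand accounts for this result.

The compounds shown do not separate the contribution of the ring in 5-(tert-butyl)-1,2-oxazol-3-yl from that of its tert-butyl group, which a 5-methyl-1,2-oxazol-3-yl group would address. Going by these compounds, it also remains open whether the standing of compound 2 is specific to methoxy or extends to an ethoxy, a hydroxyl or a dimethylamino group on the same phenyl ring.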